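Octyl series: polar piperazine amide on the side chain

This account rests on a few compounds, and the source may have more. Where it says the series, first, only, none or still open, it means among the compounds named here.

Measured so far:
compound 1 `CCCCCCCCN(C)C(=O)Cn1cc(Cc2cnc(=O)n(CC)c2)c(=O)nc1SCc1ccc(F)cc1` — 5%
compound 2 `CCCCCCCCCCCCN(C)C(=O)Cn1cc(Cc2cnc(=O)n(CCO)c2)c(=O)nc1SCc1ccc(F)cc1` — 36%

In a functional assay on a cell-free system (plasma, Oryctolagus cuniculus) for inhibition of platelet-activating factor acetylhydrolase (Homo sapiens), tested at 100 nM (on this read-out higher numbers stand for more inhibition at the one concentration tested (going by the name of the read-out) and lower numbers for less inhibition), compound 1 stands lowest of the two numbers; compound 2 sits higher, beyond the scatter, but differs from compound 1 in more than one place, so the two values show only that a gap exists. Compound 3 `CCCCCCCCN(C)C(=O)Cn1cc(Cc2cnc(=O)n(CC(=O)N3CCN(C)CC3)c2)c(=O)nc1SCc1ccc(F)cc1` is not yet measured. It differs from compound 1 by (4-methylpiperazin-1-yl)carbonyl in place of methyl on a saturated chain carbon bound to an aromatic nitrogen, the same difference read one bond further out being ethyl to ((4-methylpiperazin-1-yl)carbonyl)methyl. Among the compounds with values here, no single-point step is known here, so the step of a number 10 percentage points higher from compound 1 to compound 3 (within the scatter) is an expectation only, estimated small and upward, possibly within scatter. Compound 3 is expected to give 15% in this assay, with a range of 0% to 40%.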

Compound 3, a percentage reported as inhibition, at one concentration (the size of the read-out at that concentration, not a potency): 40%
Compound 3: the middle estimate sits 25 percentage points below what was measured; the range from low to high includes it.
By their numbers in this assay, from the lowest: compound 1; then compounds 2 and 3 (each within the scatter of the next).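

In this assay the series gains its first step in one place, a number 35 percentage points higher from compound 1 to compound 3 (beyond the scatter) with (4-methylpiperazin-1-yl)carbonyl in place of methyl. On this saturated chain carbon bound to an aromatic nitrogen, a much larger group with a six-membered non-aromatic ring therefore raises inhibition rather than abolishing it. No measurement at hand explains the rise. Which part of the new group carries the step remains open, and a morpholine amide, a dimethylamide or a carboxylic acid at this place would separate those parts. Also open, on these data alone, is whether the step holds with a dodecyl chain on the amide nitrogen.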